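Trimethoxyphenyl exchange on compound 3: working notes

The source may report more compounds than this note shows. Statements on the series, on what has been measured and on what is new or still open speak of the compounds shown alone.

Measured so far in a functional assay on SMMC-7721 cells (Homo sapiens) for cytotoxicity, read by MTT assay, with a stated time of 24 h; on this read-out higher numbers stand for weaker inhibition and lower numbers for stronger inhibition:
- compound 1 `O=C1/C(=C/c2ccccc2F)CN(S(=O)(=O)c2ccc(F)cc2)C/C1=C\c1ccccc1F` gives 8370 nM
- compound 2 `COc1cc(/C=C2\CN(S(=O)(=O)c3ccc(F)cc3)C/C(=C\c3cc(OC)c(OC)c(OC)c3)C2=O)cc(OC)c1OC` gives 3840 nM
- compound 3 `COc1cc(/C=C2\CN(S(=O)(=O)c3ccc(F)cc3)C/C(=C\c3ccccc3F)C2=O)cc(OC)c1` gives 6890 nM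

Compound 3 stands within the scatter of both other measured compounds, so its place among the three numbers carries little weight. The next structure is compound 4 `COc1cc(/C=C2\CN(S(=O)(=O)c3ccc(F)cc3)C/C(=C\c3cc(OC)c(OC)c(OC)c3)C2=O)cc(OC)c1`. The change is 3,4,5-trimethoxyphenyl in place of 2-fluorophenyl on a double-bonded chain carbon bound to a double-bonded ring carbon.

For the measured compounds named here, no measured step isolates this exchange. The closest is a 1.2-fold lower number from compound 1 to compound 3 (0.08 log units; within the scatter), where 3,5-dimethoxyphenyl took the place of 2-fluorophenyl at the same kind of carbon, and that step stayed within the scatter. Compound 2, which also carries 3,4,5-trimethoxyphenyl, reads 3840 nM and so also lies within the scatter of compound 3. Together these give no ground for a large move in this assay, and no step beyond the scatter is expected. The expected step, a 1.3-fold lower number from compound 3 to compound 4 (0.12 log units; within the scatter), is therefore small. The estimate for compound 4 is 5200 nM, with an expected range from 2700 nM to 9500 nM.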

Compound 4, half-maximal inhibitory concentration: 5420 nM
Beside the measured number, compound 4's estimate is 1.0-fold (0.02 log units) below it; low and high end bracket the measured number.
By their numbers in this assay, from the lowest: compounds 2, 4, 3 and 1 (each within the scatter of the next, the first and the last beyond it).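

In this assay, the exchange of 2-fluorophenyl for 3,4,5-trimethoxyphenyl on a double-bonded chain carbon bound to a double-bonded ring carbon can now be read on its own (a 1.3-fold lower number from compound 3 to compound 4 (0.10 log units; within the scatter)), and this position accepts a group with more heavy atoms and with hydrogen-bond acceptors without a step beyond the scatter. The pair of compounds carrying 3,4,5-trimethoxyphenyl and 3,5-dimethoxyphenyl adds a second single exchange, hydrogen in place of methoxy on an aromatic carbon (a 1.4-fold higher number from compound 2 to compound 4 (0.15 log units; within the scatter)), and this step also stays within the scatter, so the methoxy pattern on this ring has shown no readable effect so far. No measurement at hand accounts for the size of either step.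

Every group shown at this kind of carbon is an aromatic ring of carbon only, so whether an amine, a carboxylic acid or a longer chain there would move the number beyond the scatter stays open. As far as these compounds go, the rest of the shared core is the same throughout, and whether these small steps would hold on a different core also stays open.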